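Removing the chloro from compound 1: expected outcome

The source may hold more compounds than are shown below. What is called first, only, known or untested is meant among the compounds shown, and "the series" means these compounds.

Measured so far in a functional assay on MGC-803 cells (Homo sapiens) for antiproliferative activity, read by MTT assay, with a stated time of 72 h; on this read-out higher numbers stand for weaker inhibition and lower numbers for stronger inhibition:
compound 1 `O=C(COc1ccc(C(=O)/C=C/c2ccccc2Cl)cc1)N[C@H]1CCOC1=O` — 27100 nM
compound 2 `O=C(CNc1ccccc1F)N[C@H]1CCOC1=O` — > 64000 nM, a limit of the assay and not a number

For the measured compounds named here, compound 1 holds the only actual number in this assay. The other value, that of compound 2, is a limit only: the limit of > 64000 nM in this assay, at which 1 of the 2 values shown sits. Going by the values given here, compound 1 and compound 2 differ in more than one place, so no single step between them is counted, and their two values show no more than that compound 1 gives a number where compound 2 gives none.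

Compound 3 `O=C(COc1ccc(C(=O)/C=C/c2ccccc2)cc1)N[C@H]1CCOC1=O` is not yet measured. It differs from compound 1 in one place: hydrogen in place of chloro on an aromatic carbon. Among the compounds with values here, no step between measured compounds is available that would tell how this change plays out in this assay, so the expectation rests on the change alone and is held close to compound 1. A step of no more than the usual scatter is expected, if anything towards weaker inhibition: a 1.3-fold higher number from compound 1 to compound 3 (0.11 log units; within the scatter). Compound 3 is thus estimated at 35000 nM, with a range from 14000 nM to 80000 nM.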

Compound 3, half-maximal inhibitory concentration: > 64000 nM
Compound 3 gave a limit, no number; the forecaster's own chance of this, stated with the estimate: 25%; at least 1.8-fold (0.26 log units) between middle value and limit.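

In this assay, for the compounds shown here, this is the first step that can be read at a single place: going from 2-chlorophenyl to phenyl gives an at least 2.3-fold higher number from compound 1 to compound 3 (0.37 log units; beyond the scatter). The earlier compounds shown here differed in more than one place and could not isolate any group, whereas this pair shows that the chloro on an aromatic carbon, ortho to a large group, matters in this assay, since with hydrogen there the measurable inhibition of compound 1 is no longer seen. Only a lower bound can be put on this step because compound 3, at > 64000 nM, stands at a limit of the assay and not at a number: the limit of > 64000 nM in this assay, at which 2 of the 3 values shown sit.

The compounds shown leave open whether the step belongs to chloro itself or whether another group at this place, such as bromo, methyl, methoxy or trifluoromethyl, would hold or improve on the number of compound 1. They also leave open whether chloro on another carbon of the same ring would do the same, and how far the rest of the core of compound 1 contributes.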